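Series notes: methoxy to hydroxy on the anilide of compound 1

This account rests on a few compounds, and the source may have more. Where it says the series, first, only, none or still open, it means among the compounds named here.

Three compounds of this series have numbers in a functional assay on PC-3 cells (Homo sapiens) for cytotoxicity, read by sulforhodamine B assay, with a stated time of 72 h; on this read-out lower numbers stand for stronger inhibition of growth and higher numbers for weaker inhibition of growth. Compound 1 `COc1ccc(NC(=O)C2CCc3ccccc3N2)cc1` gives 56900 nM in this assay, the highest of the three numbers. Compound 3 `O=C(Nc1ccccc1O)C1CCc2ccccc2N1C(=O)c1ccc(Cl)cc1`, which carries a hydroxy group on the anilide and an acyl group on the core nitrogen, gives 25100 nM in this assay, a gap to compound 1 that is beyond the scatter. Compound 2 `O=C(Nc1ccccc1C(F)(F)F)C1CCc2ccccc2N1C(=O)c1ccccc1Cl`, with a trifluoromethyl group on the anilide and another acyl group on the core nitrogen, gives 5140 nM in this assay, the furthest from compound 1 and also beyond the scatter. No pair among these three differs in one place only, so no single step can be read from the measured set; compounds 2 and 3 each differ from compound 1 in two places at once.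

Compound 4 `O=C(Nc1ccc(O)cc1)C1CCc2ccccc2N1` is not yet measured. It differs from compound 1 by hydrogen in place of methyl on an oxygen on an aromatic ring; cut one bond further out, the change reads methoxy to hydroxy. Nothing in the measured set isolates this change. The step from compound 1 to compound 4 is therefore expected to stay within the scatter, with no direction that can be supported, and is estimated as a 1.1-fold lower number from compound 1 to compound 4 (0.06 log units; within the scatter). Compound 4 is expected to give about 50000 nM in this assay, in a range from 20000 nM to 125000 nM.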

Compound 4, concentration for 50% growth inhibition: > 100000 nM
Compound 4: a limit, no number; the forecaster's own chance of this, stated with the estimate: 25%; at least 2.0-fold (0.30 log units) between middle value and limit.
By their numbers in this assay, from the lowest: compound 2; then compound 3; then compound 1. At a limit, above all of these: compound 4.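

In this assay compound 4 gives > 100000 nM, which is a limit of the assay and not a number. Hydrogen in place of methyl on an oxygen on an aromatic ring gives an at least 1.7-fold higher number from compound 1 to compound 4 (0.24 log units; that floor lies within the scatter), the first reading of a change in one place in this series; it shows no lower number on going from methoxy to hydroxy, though the floor of the step does not establish a real rise, and its true size stays unknown. Going by these compounds alone, the reading of this step therefore rests on a single limit, the only one so far: the limit of > 100000 nM in this assay, at which 1 of the 4 values shown sits.

Going by these compounds, it remains open whether methoxy to hydroxy reads the same way on a compound bearing the acyl groups of compound 2 or compound 3, since neither of those has a partner that differs from it in one place only. On these data alone, it also remains open how a longer chain on the same oxygen, such as ethoxy, or an amine in place of the methoxy group, would read against compound 1 on this growth read-out.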